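Methyl on the Double-Bonded Chain Carbon: Two Cores Compared

The compounds below may be only part of what the source reports. "The series", "measured", "known", "first", "only" and "open" are said of these compounds alone.

Of the compounds shown here, three have been measured in a functional assay with Cavia porcellus as the target (a lower number here means a stronger inhibitor, a higher number a weaker inhibitor), and a fourth awaits. Compound 1 `C=CC[N+](C)(C)c1cccc(O)c1` carries an allyl chain on the charged nitrogen, and in this assay compound 1 gives 13000 nM. Compound 2 `C=CC[N+](C)(C)c1ccc(O)cc1` is built from the same atoms joined differently; the difference between the two cores is not broken down here. For compound 2 this assay reports only a limit, > 3000 nM. Compound 3 `C=C(C)C[N+](C)(C)c1cccc(O)c1` differs from compound 1 by methyl in place of hydrogen on a double-bonded chain carbon bound to a saturated chain carbon. For compound 3 the assay again returns only a limit, > 3000 nM. The step that the limit leaves unreadable from compound 1 to compound 3 cannot be sized because the limit of > 3000 nM in this assay, at which 2 of the 3 values shown sit, covers compound 3 and hides where it truly lies.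

Compound 4 `C=C(C)C[N+](C)(C)c1ccc(O)cc1` stands to compound 2 as compound 3 stands to compound 1: the difference is methyl in place of hydrogen on a double-bonded chain carbon bound to a saturated chain carbon, the same change at the same place. Going by the values given here, compound 2 sits at a limit, so no measured step on its core can be read. The step is expected to be a step that the limit leaves unreadable from compound 2 to compound 4. Among the compounds with values here, this expectation rests mainly on compound 1, which gives 13000 nM in this assay as the only number in the set. Compound 4 is therefore estimated at 15000 nM, with a range from 4000 nM to 60000 nM, and it is expected that this assay will most likely report another limit rather than a number.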

Compound 4, half-maximal inhibitory concentration: > 3000 nM
Compound 4 ended at the assay's limit; the forecaster's own chance of this, stated with the estimate: 80%; the middle value does not contradict the limit.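

In this assay compound 4 gives > 3000 nM, which is a limit and not a number. No new step can be read between compound 2 and compound 4, because both compounds stand at a limit: the limit of > 3000 nM in this assay, at which 3 of the 4 values shown sit. The compounds shown leave open whether methyl in place of hydrogen on this chain carbon changes potency on either core, and how compound 2, compound 3 and compound 4 truly stand against compound 1.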